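A few compounds are considered here, and "the series" means these few. Any claim that something is new, unique, unknown or untested is made for them only; others in the source may bear on it.

Three compounds sharing one core were tested in a functional assay on the whole organism (artery, strain albino) with Rattus norvegicus as the target, with a stated time of 15 min, at a dose of 10 mg/kg by the oral route; a higher number here means more inhibition at the dose given (going by the name of the read-out), a lower number less inhibition. Compound 1 `COc1ccc(C2N=C(SCc3ccc(Cl)cc3)NC(C)=C2C(=O)Nc2ccc(F)cc2)cc1OC` gives 3.1%. Compound 2 `COc1ccc(C2N=C(SCc3ccc(F)cc3)NC(C)=C2C(=O)Nc2ccc(F)cc2)cc1OC` gives 3.6%. Compound 3 `CC1=C(C(=O)Nc2ccc(F)cc2)C(c2ccc([N+](=O)[O-])cc2)N=C(SCc2ccc(Cl)cc2)N1` gives 3.6%. The change fluoro in place of chloro on an aromatic carbon made a step of a number 0.5 percentage points higher from compound 1 to compound 2 (within the scatter). The core of compound 1 and that of compound 3 differ by 4-nitrophenyl in place of 3,4-dimethoxyphenyl on a saturated ring carbon, which made a step of a number 0.5 percentage points higher from compound 1 to compound 3 (within the scatter). Compound 4 `CC1=C(C(=O)Nc2ccc(F)cc2)C(c2ccc([N+](=O)[O-])cc2)N=C(SCc2ccc(F)cc2)N1` has not been measured; it differs from compound 3 by fluoro in place of chloro on an aromatic carbon, the same change as the earlier one, at the same place. Since the earlier step was a number 0.5 percentage points higher from compound 1 to compound 2 (within the scatter), the step expected here is a number 0.5 percentage points higher from compound 3 to compound 4 (within the scatter), of a like size. Compound 4 is expected to give 4.1%, probably between -5% and 13%.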

Compound 4, a percentage reported as inhibition, in the whole organism at one dose (the size of the read-out at that dose, not a potency): 3.1%
Estimate against measurement, compound 4: 1 percentage points above, within the range that was stated.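

In this assay, fluoro in place of chloro made a number 0.5 percentage points lower from compound 3 to compound 4 (within the scatter), and 4-nitrophenyl in place of 3,4-dimethoxyphenyl made a number 0.5 percentage points lower from compound 2 to compound 4 (within the scatter). The fluoro change gave steps on the two cores that cannot be told apart: the same change on two cores in this assay, a number 0.5 percentage points higher (within the scatter) from compound 1 to compound 2 and a number 0.5 percentage points lower (within the scatter) from compound 3 to compound 4, 1 percentage points apart, within the scatter of two such steps. For the compounds shown here, the same holds for the 4-nitrophenyl change, but no step here stands out from the scatter, so this does not show that either change has any effect, or that a real effect would carry from one core to another: the same change on two cores in this assay, a number 0.5 percentage points higher (within the scatter) from compound 1 to compound 3 and a number 0.5 percentage points lower (within the scatter) from compound 2 to compound 4, 1 percentage points apart, within the scatter of two such steps.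

On these data alone, all four compounds give low numbers at a single dose, so it remains open whether this series can reach clearly stronger inhibition. The compounds shown also leave open what an amine or a carboxylic acid would do in place of the (4-fluorobenzyl)sulfanyl group.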